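This account rests on a few compounds, and the source may have more. Where it says the series, first, only, none or still open, it means among the compounds named here.

Measured so far in a functional assay on the whole organism for antagonist activity, with Mus musculus as the target; on this read-out higher numbers stand for an effect only at larger amounts of compound and lower numbers for an effect already at smaller amounts:
- compound 1 `COc1cc(N)c(Cl)cc1NC(=O)C1CCN(CC2CCCC2)CC1` gives > 10 mg/kg, a limit of the assay and not a number.
- compound 2 `COc1cc(N)c(Cl)cc1NC(=O)C1CCN(Cc2ccc(O)cc2)CC1` gives > 8 mg/kg, likewise only a limit.

Compound 2 thus stands at a limit in this assay, with no number to place it. For the measured compounds named here, the single measured step, a step that the two limits leave unreadable from compound 1 to compound 2, is unreadable, since the limit of > 10 mg/kg in this assay, at which 1 of the 2 values shown sits, and the limit of > 8 mg/kg in this assay, at which 1 of the 2 values shown sits, both sit at limits. Compound 3 `COc1cc(N)c(Cl)cc1NC(=O)C1CCN(Cc2ccsc2)CC1` carries the change (thiophen-3-yl in place of 4-hydroxyphenyl on a saturated chain carbon bound to an amine nitrogen in a ring). No readable step bears on this change, so no direction can be expected beyond the scatter. For compound 3 the expected step is a step that the limit leaves unreadable from compound 2 to compound 3. Compound 3 is therefore estimated at 10 mg/kg, ranging from 3 mg/kg to 30 mg/kg, most likely again only a limit.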

Compound 3, dose for half-maximal effect: 3.4 mg/kg
Compound 3: middle estimate off by 2.9-fold (0.47 log units), on the high side; low and high end bracket the measured number.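

In this assay, for the compounds shown here, compound 3 is the first compound here to give a number and not a limit, on a saturated chain carbon bound to an amine nitrogen in a ring. Thiophen-3-yl in place of 4-hydroxyphenyl gives an at least 2.3-fold lower number from compound 2 to compound 3 (0.37 log units; beyond the scatter), and in place of cyclopentyl it gives an at least 2.9-fold lower number from compound 1 to compound 3 (0.46 log units; beyond the scatter). As far as these compounds go, both sizes stay open-ended because each step starts from a limit: the limit of > 8 mg/kg in this assay, at which 1 of the 3 values shown sits, and (the limit of > 10 mg/kg in this assay, at which 1 of the 3 values shown sits).

From the compounds shown here alone, whether a plain phenyl or a furan ring at this place would match thiophen-3-yl stays open.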